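A small aromatic swap on compound 3

A few compounds are considered here, and "the series" means these few. Any claim that something is new, unique, unknown or untested is made for them only; others in the source may bear on it.

Three related compounds have been tested so far. In a functional assay on A375P cells (Homo sapiens) for inhibition, read by MTT assay, with a stated time of 24 h (on this read-out higher numbers stand for weaker inhibition of growth and lower numbers for stronger inhibition of growth), compound 1 `O=C1CC(c2ccc(NC(=O)Nc3ccc(Cl)c(C(F)(F)F)c3)cc2)=Nc2cnn(Cc3ccccc3)c2N1` gives 1190 nM. Compound 2 `Cc1cn(-c2cc(NC(=O)Nc3ccc(C4=Nc5cnn(Cc6ccccc6)c5NC(=O)C4)cc3)cc(C(F)(F)F)c2)cn1` gives only a limit, > 30000 nM, and no actual number. Compound 3 `COc1ccc(Cn2ncc3c2NC(=O)CC(c2cccc(NC(=O)Nc4ccc(Cl)cc4)c2)=N3)cc1` gives 640 nM, which lies within the usual scatter of compound 1, so these two results cannot be told apart.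

The next compound, compound 4 `COc1ccc(Cn2ncc3c2NC(=O)CC(c2cccc(NC(=O)Nc4cccc(C(F)(F)F)c4)c2)=N3)cc1`, differs from compound 3 in one place: 3-(trifluoromethyl)phenyl in place of 4-chlorophenyl on an amide-type nitrogen. In words, 3-(trifluoromethyl)phenyl stands in place of 4-chlorophenyl on an amide-type nitrogen.

Within the data shown here, no tested pair shows this change on its own, so any expectation here is loose. Compound 1 also carries a trifluoromethyl group and gives 1190 nM, so that group does not rule out a measurable value. Compound 2 carries one as well, and its result is the limit > 30000 nM, so the range has to stay wide.

In this assay the expected change is a 1.3-fold higher number from compound 3 to compound 4 (0.10 log units; within the scatter), which would be no step beyond the scatter. For compound 4 the estimated value is 800 nM, with an expected range of 250 nM to 3500 nM.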

Compound 4, concentration for 50% growth inhibition: 250 nM
Compound 4: the middle estimate sits 3.2-fold (0.51 log units) above what was measured; measured number inside the range.
By their numbers in this assay, from the lowest: compound 4; then compounds 3 and 1 (each within the scatter of the next). At a limit, above all of these: compound 2.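

In this assay, this is the first single change among the compounds shown that can be read as a step, and it goes beyond the scatter, with a 2.6-fold lower number from compound 3 to compound 4 (0.41 log units; beyond the scatter) as the result. It shows that the aromatic group on this amide-type nitrogen is not a silent part of the molecule: on the core shared by these two compounds, 3-(trifluoromethyl)phenyl gives stronger inhibition of growth than 4-chlorophenyl, though the step is modest. Nothing shown gives a measured reason for this step, so it stands as an observation only.

The swap alters both the substituent and its place on the ring, so 3-chlorophenyl and 4-(trifluoromethyl)phenyl on the same nitrogen would be needed to tell those two parts apart. From the compounds shown here alone, it also remains open whether a phenyl ring carrying an amine or a carboxylic acid at this position would keep the growth inhibition, and whether the same swap would have a similar effect with a benzyl group in place of the 4-methoxybenzyl group of compound 4.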